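Replacing the anilide of compound 1 with a free acid

The compounds below may be only part of what the source reports. "The series", "measured", "known", "first", "only" and "open" are said of these compounds alone.

Measured set in a functional assay on QGY7701 cells (Homo sapiens) for cytotoxicity, read by MTT assay, with a stated time of 24 h; a lower number here means a stronger inhibitor, a higher number a weaker inhibitor:
compound 1 `C=CC1=C(C(=O)Nc2ccccc2)C(c2ccc(Cl)c(Cl)c2)OC1` gives > 100000 nM
compound 2 `C=CC1=C(C(=O)Nc2ccccc2)C(c2ccc(OC)cc2)OC1` gives > 100000 nM
compound 3 `C=CC1=C(C(=O)Nc2ccccc2)C(c2ccc(F)cc2)OC1` gives 46700 nM

Compound 1 sits at a limit of the assay, not at a number (the limit of > 100000 nM in this assay, at which 2 of the 3 values shown sit). Compound 2 likewise sits at a limit. Compound 3 alone returns a number; the readable steps are an at least 2.1-fold lower number from compound 1 to compound 3 (0.33 log units; beyond the scatter) and an at least 2.1-fold lower number from compound 2 to compound 3 (0.33 log units; beyond the scatter), while between the two limits lies a step that the two limits leave unreadable from compound 1 to compound 2. All three changes concern the group on the saturated ring carbon and leave the amide untouched. Among the measured compounds shown here, compound 4 `C=CC1=C(C(=O)O)C(c2ccc(Cl)c(Cl)c2)OC1` differs from compound 1 in hydroxy in place of anilino on a carbonyl carbon, a change that no measured step tests. With compound 1 at a limit, no direction can be anchored, and the expected step is a number no higher from compound 1 to compound 4 (the limit leaves the size open). Compound 4 is therefore estimated near 100000 nM, between 30000 nM and 400000 nM.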

Compound 4, half-maximal inhibitory concentration: > 100000 nM
Compound 4 ended at the assay's limit (the forecaster's own chance of this, stated with the estimate: 80%); the middle value sits exactly at the limit.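

Compound 1 and compound 4 both stand at a limit in this assay, so no step can be read between them: the limit of > 100000 nM in this assay, at which 3 of the 4 values shown sit. Whether hydroxy in place of anilino on a carbonyl carbon changes the read-out at all remains open in the compounds shown.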